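A few compounds are considered here, and "the series" means these few. Any claim that something is new, unique, unknown or untested is made for them only; others in the source may bear on it.

Measured in a functional assay on MGC-803 cells (Homo sapiens) for inhibition, read by MTT assay, with a stated time of 48 h; a higher number here means a weaker inhibitor, a lower number a stronger inhibitor:
- compound 1 `C/C=C/C(=O)N(Cc1ccc(OC)c([N+](=O)[O-])c1)c1cc(OC)c(OC)c(OC)c1`: 590 nM
- compound 2 `COc1ccc(CNc2cc(OC)c(OC)c(OC)c2)cc1[N+](=O)[O-]`: 19400 nM
- compound 3 `COc1ccc(N(Cc2cc(OC)c(OC)c(OC)c2)C(=O)CCl)cc1O`: 24500 nM

Compound 2, at 19400 nM, sits level with compound 3 within the usual scatter, and compound 1 gives a far lower number than either. The next compound, compound 4 `COc1ccc(CNc2cc(OC)c(OC)c(OC)c2)cc1F`, keeps the rest of compound 2 but carries fluoro in place of nitro on an aromatic carbon.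

Among the measured compounds shown here, only one measured step is available, a 33-fold higher number from compound 1 to compound 2 (1.52 log units; beyond the scatter), and it is large. It replaces (prop-1-en-1-yl)carbonyl on a nitrogen with hydrogen, a change elsewhere in the molecule. For the measured compounds named here, no measured pair exchanges the nitro group, so that step gives no size for this change, and the data cannot show how much the swap matters in this assay. The best anchor is therefore compound 2 itself at 19400 nM, with no clear direction expected. The expected change is small: a 1.3-fold higher number from compound 2 to compound 4 (0.11 log units; within the scatter). For compound 4 the estimated value is 25000 nM, with an expected range of 8000 nM to 80000 nM.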

Compound 4, half-maximal inhibitory concentration: 39700 nM
The estimate for compound 4 lay 1.6-fold (0.20 log units) below the measured number; the measured number falls inside the stated range.
By their numbers in this assay, from the lowest: compound 1; then compounds 2, 3 and 4 (each within the scatter of the next, the first and the last beyond it).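

Among the compounds shown here, this is the first measured exchange at this aromatic carbon, ortho to a methoxy group: in this assay, fluoro in place of nitro gives a 2.0-fold higher number from compound 2 to compound 4 (0.31 log units; beyond the scatter). The position therefore responds to what it carries, but the step is modest, far smaller than the change on the nitrogen, a 33-fold higher number from compound 1 to compound 2 (1.52 log units; beyond the scatter), so the nitro group of compound 2 matters less here than the (prop-1-en-1-yl)carbonyl group of compound 1. No measurement shown here explains why the exchange has this effect.

From the compounds shown here alone, whether an amine, a chloro group or a nitrile on the same carbon would give a lower or a higher number stays open. So does whether adding (prop-1-en-1-yl)carbonyl to the nitrogen of compound 4 would lower its number as strongly as that group does in compound 1.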